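This account rests on a few compounds, and the source may have more. Where it says the series, first, only, none or still open, it means among the compounds named here.

Measured compounds:
compound 1, `COC(=O)c1sc2cc(-c3ccsc3)cnc2c1N`, giving 12400 nM in a functional assay on NCI-H460 cells (Homo sapiens) for inhibition, read by sulforhodamine B assay, with a stated time of 48 h; on this read-out lower numbers stand for stronger inhibition of growth and higher numbers for weaker inhibition of growth
compound 2, `COC(=O)c1sc2cc(-c3cccs3)cnc2c1N`, giving 18000 nM in this assay
compound 3, `COC(=O)c1sc2cc(-c3ccc(-c4cccs4)s3)cnc2c1N`, giving 700 nM in this assay

Among these three, compound 2 is set apart only from compound 3: a 26-fold lower number from compound 2 to compound 3 (1.41 log units; beyond the scatter). Against compound 1 the picture is different, since a 1.5-fold higher number from compound 1 to compound 2 (0.16 log units; within the scatter), so compounds 1 and 2 cannot be told apart. Compound 4, `COC(=O)c1sc2cc(-c3cnn(C)c3)cnc2c1N`, is not yet measured in this assay. It differs from compound 2 in one place: 1-methyl-1H-pyrazol-4-yl in place of thiophen-2-yl on an aromatic carbon. Among the measured compounds shown here, two measured steps bear on this. The step from compound 1 to compound 2 shows that moving the attachment of a thiophene ring leaves the number within the scatter, while the step from compound 2 to compound 3 shows that a large move comes from extending the substituent by a further ring. Compound 4 neither extends the substituent nor removes it, so the change most resembles the first of these steps. The estimate for compound 4 is therefore 15000 nM, with a range of 5000 nM to 50000 nM. The expected step, a 1.2-fold lower number from compound 2 to compound 4 (0.08 log units; within the scatter), is within the scatter.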

Compound 4, concentration for 50% growth inhibition: > 150000 nM
Compound 4 gave a limit, no number; the forecaster's own chance of this, stated with the estimate: 10%; middle value at least 10-fold (1.00 log units) away from the limit.
By their numbers in this assay, from the lowest: compound 3; then compounds 1 and 2 (each within the scatter of the next). At a limit, above all of these: compound 4.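

Compound 4 gave only a limit in this assay, not a number: the limit of > 150000 nM in this assay, at which 1 of the 4 values shown sits. The earlier compounds shown here showed that thiophen-2-yl and thiophen-3-yl could not be told apart at this place on the six-membered aromatic ring, and that a large step came with a further thiophene ring. The new result shows that exchanging one five-membered aromatic ring for another, with no further ring added, also gives a step beyond the scatter, with an at least 8.3-fold higher number from compound 2 to compound 4 (0.92 log units; beyond the scatter) and an at least 12-fold higher number from compound 1 to compound 4 (1.08 log units; beyond the scatter).

The compounds shown leave open whether this step goes with the second ring nitrogen or with the methyl group, since neither an unsubstituted 1H-pyrazol-4-yl nor a phenyl ring stands among them. Among the compounds shown here, they also leave open whether a further ring on 1-methyl-1H-pyrazol-4-yl would give a step like the one a 26-fold lower number from compound 2 to compound 3 (1.41 log units; beyond the scatter).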